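The compounds below may be only part of what the source reports. "The series", "measured", "known", "first", "only" and "open" are said of these compounds alone.

Compound 1 `COc1ccc(Nc2nc(Nc3cc(C)[nH]n3)cc(N3CCN(C)CC3)n2)cc1OC` is the reference point of this small set. Among the measured compounds shown here, in a functional assay on HCT-116 cells (Homo sapiens) for antiproliferative activity, read by CCK-8 assay, with a stated time of 48 h (a lower number here means a stronger inhibitor, a higher number a weaker inhibitor), compound 1 gives 777 nM, the highest of the three numbers measured so far. Two analogues change the aryl group on the nitrogen on an aromatic ring: compound 2 `Cc1cc(Nc2cc(N3CCN(C)CC3)nc(Nc3ccc(Cl)c(F)c3)n2)n[nH]1` gives 252 nM in this assay, and compound 3 `Cc1cc(Nc2cc(N3CCN(C)CC3)nc(Nc3cccc(F)c3)n2)n[nH]1` gives 317 nM. Both moves lower the number beyond the scatter, a 3.1-fold lower number from compound 1 to compound 2 (0.49 log units; beyond the scatter) and a 2.5-fold lower number from compound 1 to compound 3 (0.39 log units; beyond the scatter). Between the two halogenated analogues the difference is a 1.3-fold higher number from compound 2 to compound 3 (0.10 log units; within the scatter), so those two values sit within the scatter of each other.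

Compound 4 `Cc1cc(Nc2cc(N3CCN(C)CC3)nc(Nc3ccc(F)c(F)c3)n2)n[nH]1` makes a closely related change from compound 1: 3,4-difluorophenyl in place of 3,4-dimethoxyphenyl on a nitrogen on an aromatic ring. The steps from compound 1 to compound 2 and from compound 1 to compound 3 bear on it directly, both replacing the 3,4-dimethoxyphenyl with a fluorine-bearing phenyl and both giving a modest lowering beyond the scatter. A step of similar size and in the same direction is expected in this assay for compound 4; the expected step is a 2.8-fold lower number from compound 1 to compound 4 (0.44 log units; beyond the scatter). On that basis compound 4 is estimated at 280 nM, with a likely range from 150 nM to 550 nM.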

Compound 4, half-maximal inhibitory concentration: 339 nM
The estimate for compound 4 lay 1.2-fold (0.08 log units) below the measured number; the range from low to high includes it.
By their numbers in this assay, from the lowest: compounds 2, 3 and 4 (each within the scatter of the next); then compound 1.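

The result extends the lowering seen with the earlier analogues to a third fluorine-bearing phenyl: there is a 2.3-fold lower number from compound 1 to compound 4 (0.36 log units; beyond the scatter), so all three analogues lie on the same side of compound 1 in this assay, and none goes against this within the set. It also shows that the aromatic carbon carrying chloro in compound 2 tolerates the change without a readable shift, with a 1.1-fold higher number from compound 3 to compound 4 (0.03 log units; within the scatter) and a 1.3-fold higher number from compound 2 to compound 4 (0.13 log units; within the scatter), so hydrogen, fluoro and chloro at this carbon cannot be told apart here, and the gain over compound 1 does not depend on which of the three is present. No measurement shown accounts for the gap between compound 1 and its halogenated analogues.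

Every analogue shown both loses the two methoxy groups and gains halogen, so it remains open which of these changes goes with the lower number, a question that an unsubstituted phenyl or a phenyl with a single methoxy group would address. From the compounds shown here alone, it also remains open whether a larger or different group at the same carbon, such as trifluoromethyl, nitrile or an amine, would stay level with compounds 2, 3 and 4 or move away from them.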